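The source may hold more compounds than are shown below. What is called first, only, known or untested is meant among the compounds shown, and "the series" means these compounds.

Compound 1 `C=C(CC)C(=O)c1ccc(OCC(=O)Nc2ccc(/C=C/C(=O)OCC)cc2)c(Cl)c1Cl`: 1700 nM
Compound 2 `C=C(CC)C(=O)c1ccc(OCC(=O)Nc2ccc(CC(=O)O)cc2)c(Cl)c1Cl`: 3200 nM

Both compounds were tested in a functional assay on CLL cells (Homo sapiens) for cytotoxicity, read by MTT assay, with a stated time of 48 h; on this read-out lower numbers stand for an effect already at smaller amounts and higher numbers for an effect only at larger amounts of compound. Only these two numbers exist so far, and compound 2, at 3200 nM, stands level with compound 1 within the usual scatter of repeated measurements.

The next structure is compound 3 `C=C(CC)C(=O)c1ccc(OCC(=O)Nc2ccc(C#N)cc2)c(Cl)c1Cl`. It keeps the shared core of compound 2 and alters one group: cyano in place of carboxymethyl on an aromatic carbon, para to a large group. cyano in place of carboxymethyl on an aromatic carbon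

Among the measured compounds shown here, one measured step bears on this change, as it concerns the same aromatic carbon: a 1.9-fold higher number from compound 1 to compound 2 (0.27 log units; within the scatter). Two clearly different groups were exchanged there, and the numbers stayed within the scatter. For the measured compounds named here, this is thin evidence, since it is a single step and no measured compound yet carries cyano. No step beyond the scatter is therefore expected in this assay, in either direction. The expected move is a 1.3-fold lower number from compound 2 to compound 3 (0.11 log units; within the scatter). Allowing for that uncertainty, compound 3 is estimated at 2500 nM, with an expected range from 900 nM to 7000 nM.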

Compound 3, half-maximal effective concentration: 7800 nM
Estimate against measurement, compound 3: 3.1-fold (0.49 log units) below; measured number above the stated range.
By their numbers in this assay, from the lowest: compounds 1 and 2 (each within the scatter of the next); then compound 3.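

In this assay, the position para to a large group turns out not to accept every group equally: cyano in place of carboxymethyl brings a 2.4-fold higher number from compound 2 to compound 3 (0.39 log units; beyond the scatter) and cyano in place of 2-(ethoxycarbonyl)ethenyl brings a 4.6-fold higher number from compound 1 to compound 3 (0.66 log units; beyond the scatter) even though the exchange between those two larger groups had stayed within the scatter. Among these three compounds, then, cyano is the group that stands apart, and both steps are modest in size, so the position matters here without any single change being dramatic. The group that enters has fewer heavy atoms than carboxymethyl and no hydrogen-bond donor, but no measurement available here explains why the number rises.

Among the compounds shown here, with only three groups at this aromatic carbon, it remains unclear whether the higher number goes with the shorter group, with cyano itself, or with neither. An amine, a carboxylic acid attached directly to the ring, or a longer chain ending in cyano on the same carbon would help separate these possibilities.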